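The source may report more compounds than this note shows. Statements on the series, on what has been measured and on what is new or still open speak of the compounds shown alone.

Working notes on the series, cytotoxicity read-out.

Of the compounds shown here, three have been measured in a functional assay on HeLa cells (Homo sapiens) for cytotoxicity, read by MTT assay, with a stated time of 72 h; on this read-out lower numbers stand for stronger inhibition and higher numbers for weaker inhibition. Compound 1 `O=C(c1cccc(C(F)(F)F)c1)N(/N=N/c1ccc([N+](=O)[O-])cc1Cl)c1ccc([N+](=O)[O-])cc1Cl` gives 1180 nM. Compound 2 `O=C(c1ccc(C(F)(F)F)cc1)N(/N=N/c1ccc([N+](=O)[O-])cc1Cl)c1ccc([N+](=O)[O-])cc1Cl` carries the same core, with the change (4-(trifluoromethyl)phenyl in place of 3-(trifluoromethyl)phenyl on a carbonyl carbon); in this assay compound 2 gives 1060 nM, and the step is a 1.1-fold lower number from compound 1 to compound 2 (0.05 log units; within the scatter). On this evidence the two placements of the trifluoromethyl on the benzoyl ring are not separated by the assay.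

Compound 3 `O=C(c1cccc(C(F)(F)F)c1)N(/N=N/c1ccc([N+](=O)[O-])cc1C(F)(F)F)c1ccc([N+](=O)[O-])cc1C(F)(F)F` has a different core; the difference between its core and that of compound 1 is not broken down here. In this assay compound 3 gives 750 nM. Its values against compound 1 and compound 2 fall inside the usual scatter of repeated measurements, so no order among the three is drawn.

Compound 4 `O=C(c1ccc(C(F)(F)F)cc1)N(/N=N/c1ccc([N+](=O)[O-])cc1C(F)(F)F)c1ccc([N+](=O)[O-])cc1C(F)(F)F` is the counterpart of compound 2 on the core of compound 3: it differs from compound 3 by 4-(trifluoromethyl)phenyl in place of 3-(trifluoromethyl)phenyl on a carbonyl carbon. The place of the change is described in the same words for both pairs, so this is the same change as from compound 1 to compound 2, made on the other core.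

For compound 4 in this assay the step is expected to be a 1.1-fold lower number from compound 3 to compound 4 (0.03 log units; within the scatter), resting on compound 1 to compound 2, where the same change gave a 1.1-fold lower number from compound 1 to compound 2 (0.05 log units; within the scatter). Compound 4 is therefore estimated at 700 nM, with a range expected from 400 nM to 1300 nM. The core change from compound 1 to compound 3 has not been measured in combination with the para benzoyl, so the estimate leans on a single prior instance of the change. The measured value for compound 4 is awaited.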

Compound 4, half-maximal inhibitory concentration: 690 nM
For compound 4 the middle estimate is 1.0-fold (0.01 log units) above the measured one, within the range that was stated.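

In this assay, replacing 3-(trifluoromethyl)phenyl with 4-(trifluoromethyl)phenyl on the carbonyl carbon of the core of compound 3 gives a 1.1-fold lower number from compound 3 to compound 4 (0.04 log units; within the scatter). Set beside the earlier step, the same change reads alike on the two cores: the same change on two cores in this assay, a 1.1-fold lower number (0.05 log units; within the scatter) from compound 1 to compound 2 and a 1.1-fold lower number (0.04 log units; within the scatter) from compound 3 to compound 4, 1.0-fold (0.01 log units) apart, within the scatter of two such steps. This shows that the change carries from one core to the other in the sense that neither core separates the two placements of the trifluoromethyl, but since both steps lie within the scatter, what carries over is the lack of a readable step, not an effect of a given size or direction, and two cores give no grounds for a rule across other cores in the series.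

The compounds shown leave open whether any replacement of the 3-(trifluoromethyl)phenyl or 4-(trifluoromethyl)phenyl group would give a step beyond the scatter, for instance a benzoyl ring carrying a carboxylic acid, an amine or a methoxy group in place of the trifluoromethyl. They also leave open whether such a larger step would keep its size from the core of compound 1 to the core of compound 3, and what a single cell line says about cytotoxicity in other cells.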